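Extending the Linker Between Cyanoguanidine and Benzamide

The source may hold more compounds than are shown below. What is called first, only, known or untested is meant among the compounds shown, and "the series" means these compounds.

Measured compounds:
compound 1, `N#CN/C(=N\CCNC(=O)c1ccccc1[N+](=O)[O-])NCCCCOc1cccc(CN2CCCCC2)c1`: 7.52
compound 2, `N#CN/C(=N\CCNC(=O)c1ccccc1)NCCCCOc1cccc(CN2CCCCC2)c1`: 7.67

Both measured compounds share a core carrying a piperidinylmethylphenoxybutyl chain on a cyanoguanidine, with a benzamide hung from the other nitrogen through a two-carbon chain. In a functional assay on cardiac atrium for antagonist activity at histamine H2 receptor (Cavia porcellus) (on this read-out lower numbers stand for lower potency and higher numbers for higher potency (the scale is a negative logarithm)), compound 2 gives 7.67, and compound 1 gives 7.52 in this assay. Within the data shown here, the only step recorded, a number 0.15 log units higher from compound 1 to compound 2 (within the scatter), is the loss of a nitro group from the benzamide ring, and the two values lie within the scatter of each other.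

Compound 3, `N#CN/C(=N\CCCNC(=O)c1ccccc1)NCCCCOc1cccc(CN2CCCCC2)c1`, differs from compound 2 by benzamidomethyl in place of benzamido on a saturated chain carbon, two bonds along the chain from a double-bonded nitrogen. Among the measured compounds shown here, no measured step touches this part of the molecule; the one step available concerns a substituent on the aromatic ring and says nothing about the length of the chain to the amide. The expectation therefore rests on the change alone, and an estimated step of a number 0.07 log units lower from compound 2 to compound 3 (within the scatter), within the scatter, is assumed. For compound 3 the estimate in this assay is 7.6, with a range from 7 to 8.2.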

Compound 3, negative logarithm of the antagonist equilibrium constant: 6.6
Beside the measured number, compound 3's estimate is 1.00 log units above it; measured number outside the range, below it.
By their numbers in this assay, from the lowest: compound 3; then compounds 1 and 2 (each within the scatter of the next).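

In this assay, benzamidomethyl in place of benzamido on a saturated chain carbon, two bonds along the chain from a double-bonded nitrogen, gives a number 1.07 log units lower from compound 2 to compound 3 (beyond the scatter), so this position responds clearly to the change, whereas the earlier step on the aromatic ring stayed within the scatter. Among these compounds, the same change read against the nitro-bearing benzamide, which also loses the nitro group, gives a number 0.92 log units lower from compound 1 to compound 3 (beyond the scatter), so the loss appears from both of the earlier compounds. Nothing available bears on the reason for this loss in potency.

The compounds shown leave open whether the number keeps falling with 2-benzamidoethyl or 3-benzamidopropyl at this place, and whether a nitro group on the aromatic ring of compound 3 would stay within the scatter as it does with compound 2. They also leave open how an amine or a carboxylic acid in place of the benzamido group at this position would read on this scale.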